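Hydroxy on the Sulfonyl Chain: Effect on Microsomal Stability

The compounds below may be only part of what the source reports. "The series", "measured", "known", "first", "only" and "open" are said of these compounds alone.

Compound 1 `CCCc1cnc(N2CCC(C3Cc4cc(C5=CCN(S(=O)(=O)CCC)CC5)cc(F)c4O3)CC2)nc1` and compound 3 `CCCc1cnc(N2CCC(C3Cc4cc(C5=CCN(S(=O)(=O)CCCO)CC5)cc(F)c4O3)CC2)nc1` share one core, while compound 2 `CCCc1cnc(N2CCC(C3(C)Cc4cc(C5=CCN(S(=O)(=O)CCC)CC5)ccc4O3)CC2)nc1` and compound 4 `CCCc1cnc(N2CCC(C3(C)Cc4cc(C5=CCN(S(=O)(=O)CCCO)CC5)ccc4O3)CC2)nc1` share another; the difference between the two cores is not broken down here. In an ADME assay (liver) for metabolic stability, with Liver microsome (Homo sapiens) as the target, using microsomes, with a stated time of 10 min (a lower number here means that less of the compound is left, a higher number that more of the compound is left), compound 1 gives 97%, and compound 3 gives 100%. The change between them is hydroxy in place of hydrogen on a saturated chain carbon, three bonds along the chain from a sulfonyl sulfur, and it made the step of a number 3 percentage points higher from compound 1 to compound 3 (within the scatter). In this assay compound 2 gives 68%, the lowest of the three measured numbers, with compound 1 and compound 3 both beyond the scatter above it. Compound 4 carries the same change on the core of compound 2, namely (hydroxy in place of hydrogen on a saturated chain carbon, three bonds along the chain from a sulfonyl sulfur). Because the earlier step was a number 3 percentage points higher from compound 1 to compound 3 (within the scatter), the step from compound 2 to compound 4 is expected to be small, a number 4 percentage points higher from compound 2 to compound 4 (within the scatter). Compound 4 is therefore estimated at 72%, most likely between 55% and 90%.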

Compound 4, percent of the compound remaining: 72%
Estimate against measurement, compound 4: no gap at the digits printed, and the stated range covers the measured number.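

In this assay, changing propyl to 3-hydroxypropyl gives a number 4 percentage points higher from compound 2 to compound 4 (within the scatter), and compound 2, at 68%, had room for a rise that did not appear. The change therefore behaves alike on the two cores: the same change on two cores in this assay, a number 3 percentage points higher (within the scatter) from compound 1 to compound 3 and a number 4 percentage points higher (within the scatter) from compound 2 to compound 4, 1 percentage points apart, within the scatter of two such steps. Going by these compounds alone, this shows only that the hydroxy group made no readable difference to this read-out on these two cores, and it does not show that the same would hold on a third core.

Still open, as far as these compounds go, is whether an amine, a carboxylic acid or a longer chain at this place would leave the number just as it stands. The compounds shown also leave open how the hydroxy change behaves in any other assay.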